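The source may hold more compounds than are shown below. What is called first, only, known or untested is meant among the compounds shown, and "the series" means these compounds.

Measured compounds:
- compound 1, `Cc1c(Oc2ccccc2)ccc[n+]1[O-]`: in a functional assay on the whole organism with Mus musculus as the target, in the maximal electroshock model, with a stated time of 30 min (a higher number here means that more compound is needed for the effect, a lower number that less compound is needed), compound 1 gives 300 mg/kg
- compound 2, `N#Cc1cc[n+]([O-])cc1Oc1ccccc1`: in this assay compound 2 gives 300 mg/kg
- compound 3, `Cc1cc[n+]([O-])cc1Oc1ccc(Cl)cc1`: in this assay compound 3 gives 100 mg/kg

Compound 3 has the lowest number of the three, and its distance to each of the other two lies beyond the scatter, so it needs the least compound for the effect. Compound 1 and compound 2 return the same number; nothing separates them.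

Compound 4, `Cc1ccc(Oc2c[n+]([O-])ccc2C)cc1`, differs from compound 3 in one place only: methyl in place of chloro on an aromatic carbon. Among the measured compounds shown here, no pair of measured compounds shares this change, so there is no step to lean on, and the series is too small to claim any pattern.

For the measured compounds named here, because compound 3 sits at 100 mg/kg and the methyl-bearing analogues have no precedent here, the step of a 1.5-fold higher number from compound 3 to compound 4 (0.18 log units; within the scatter) is expected to be small, most likely upward or none beyond the scatter. For compound 4 a minimum effective dose of 150 mg/kg is estimated, with the range 100 mg/kg to 300 mg/kg.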

Compound 4, minimum effective dose: 300 mg/kg
The estimate for compound 4 lay 2.0-fold (0.30 log units) below the measured number, within the range that was stated.
By their numbers in this assay, from the lowest: compound 3; then compounds 1, 2 and 4 (each within the scatter of the next).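

Among the compounds shown here, this is the first step that differs in one place only: in this assay, methyl in place of chloro on an aromatic carbon, para to a group of 9 heavy atoms, gives a 3.0-fold higher number from compound 3 to compound 4 (0.48 log units; beyond the scatter) and so lies beyond the scatter. The two groups match in heavy-atom count, hydrogen-bond donors, hydrogen-bond acceptors and net charge, so these counts alone do not settle the read-out at this place, and the identity of the group does matter here. No measurement shown explains why chloro and methyl part in this way.

One pair cannot show a trend across groups at this place, so a bromo, a methoxy or an amine there remains an open question. Also open, going by these compounds, is whether the same change would give a step of similar size on the core of compound 1 or compound 2.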